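Truncating the hexynyl chain on the amino core

The compounds below may be only part of what the source reports. "The series", "measured", "known", "first", "only" and "open" are said of these compounds alone.

Compound 1 `CCCCCC#Cc1cn([C@@H]2O[C@H](CO)[C@@H](O)[C@H](O)[C@H]2O)c(=O)nc1N` gives only a limit in a functional assay on L1210 cells (Mus musculus) for cytotoxicity, with a stated time of 48 h (on this read-out lower numbers stand for stronger inhibition and higher numbers for weaker inhibition), namely >= 250000 nM, so its place among the measured values is open. Compound 2 `O=c1nc(O)c(C#Cc2ccccc2)cn1[C@@H]1O[C@H](CO)[C@@H](O)[C@H](O)[C@H]1O` gives 6200 nM in this assay, and compound 3 `CCCCCc1ccc(C#Cc2cn([C@@H]3O[C@H](CO)[C@@H](O)[C@H](O)[C@H]3O)c(=O)nc2O)cc1` gives 70000 nM. For the measured compounds named here, the one measured step, an 11-fold higher number from compound 2 to compound 3 (1.05 log units; beyond the scatter), shows that adding a pentyl group raises the number. Compound 4 `C#Cc1cn([C@@H]2O[C@H](CO)[C@@H](O)[C@H](O)[C@H]2O)c(=O)nc1N` differs from compound 1 by hydrogen in place of pentyl on a triple-bonded carbon. This runs the measured step in reverse, though on a triple-bonded carbon rather than an aromatic one and on a different core, so the bearing is loose. Because the limit of >= 250000 nM in this assay, at which 1 of the 3 values shown sits, is a limit, the step of an at least 5.0-fold lower number from compound 1 to compound 4 (0.69 log units; beyond the scatter) is expected to bring compound 4 into the measurable range. Compound 4 is estimated at 50000 nM, with a range from 10000 nM to 250000 nM.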

Compound 4, half-maximal inhibitory concentration: >= 250000 nM
Compound 4 gave a limit, no number (the forecaster's own chance of this, stated with the estimate: 30%); middle value at least 5.0-fold (0.69 log units) from the limit.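

Compound 1 and compound 4 both sit at a limit of the assay, so no step can be read between them: the limit of >= 250000 nM in this assay, at which 2 of the 4 values shown sit. As far as these compounds go, whether any chain on the core of compound 1 gives a measurable number stays open.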